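Chloro on a phenyl of compound 3

The source may report more compounds than this note shows. Statements on the series, on what has been measured and on what is new or still open speak of the compounds shown alone.

Measured in an ADME assay on HaCaT cells (Homo sapiens) for cytotoxicity, read by MTT assay, with a stated time of 48 h; a higher number here means a weaker inhibitor, a lower number a stronger inhibitor:
- compound 1 `Clc1ccc2[nH]c(-c3cn(-c4ccccc4)nc3-c3ccccc3)nc2c1` gives > 50000 nM as a limit
- compound 2 `COc1ccc2[nH]c(-c3cn(-c4ccccc4)nc3-c3ccccc3)nc2c1` gives > 50000 nM as a limit
- compound 3 `FC(F)(F)c1ccc2[nH]c(-c3cn(-c4ccccc4)nc3-c3ccccc3)nc2c1` gives 37200 nM as a number

For the measured compounds named here, compound 3 holds the only number. Compounds 1 and 2 rest at the limit of > 50000 nM in this assay, at which 2 of the 3 values shown sit, and give no number.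

Compound 4 `FC(F)(F)c1ccc2[nH]c(-c3cn(-c4ccccc4)nc3-c3ccc(Cl)cc3)nc2c1` carries chloro in place of hydrogen on an aromatic carbon, phenyl to 4-chlorophenyl (chloro in place of hydrogen on an aromatic carbon). The readable steps are an at least 1.3-fold lower number from compound 1 to compound 3 (0.12 log units; that floor lies within the scatter) and an at least 1.3-fold lower number from compound 2 to compound 3 (0.12 log units; that floor lies within the scatter) and neither changes a phenyl, so they guide the size only loosely. No step beyond the scatter is expected in this assay (estimated: a 1.2-fold lower number from compound 3 to compound 4 (0.09 log units; within the scatter)). For compound 4 the estimated value is 30000 nM (expected range 13000 nM to 50000 nM).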

Compound 4, half-maximal inhibitory concentration: 41800 nM
Estimate against measurement, compound 4: 1.4-fold (0.14 log units) below; measured number inside the range.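

In this assay, for the compounds shown here, this is the first readable step on a phenyl: chloro in place of hydrogen on an aromatic carbon gives a 1.1-fold higher number from compound 3 to compound 4 (0.05 log units; within the scatter). With trifluoromethyl kept on the core, phenyl and 4-chlorophenyl therefore read as level. The series still offers few numbers for comparison: the limit of > 50000 nM in this assay, at which 2 of the 4 values shown sit.

On these data alone, whether an amine or a carboxylic acid in place of chloro on this phenyl would give a step beyond the scatter stays open. So does whether 4-chlorophenyl reads the same without trifluoromethyl on the core.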